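What one added fluoro may change in compound 3

This account rests on a few compounds, and the source may have more. Where it says the series, first, only, none or still open, it means among the compounds named here.

Measured in an ADME assay on cells (Macrophage, Mus musculus) for cytotoxicity, read by resazurin assay, with a stated time of 3 days (a higher number here means a weaker inhibitor, a lower number a stronger inhibitor), so far:
compound 1 `O=C(Nc1cccc(C(F)(F)F)c1)c1cc(Cl)ccc1O` at 5900 nM
compound 2 `O=C(Nc1cc(C(F)(F)F)ccc1C(F)(F)F)c1cc(Cl)ccc1O` at 6600 nM

Compound 1 and compound 2 lie within the scatter of each other, so neither ranks above the other. Compound 3 `O=C(Nc1cccc(C(F)(F)F)c1F)c1cc(Cl)ccc1O` differs from compound 1 by one change, fluoro in place of hydrogen on an aromatic carbon. Among the measured compounds shown here, one measured step bears on this, also a replacement of hydrogen on an aromatic carbon, there by trifluoromethyl (a 1.1-fold higher number from compound 1 to compound 2 (0.05 log units; within the scatter)). It stayed within the scatter, though one step is thin evidence. No shift beyond the scatter is therefore expected in this assay in either direction. The expected step is a 1.0-fold higher number from compound 1 to compound 3 (0.01 log units; within the scatter) in size. Compound 3 is estimated at 6000 nM (expected range 3000 nM to 12000 nM).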

Compound 3, half-maximal inhibitory concentration: 5300 nM
Beside the measured number, compound 3's estimate is 1.1-fold (0.05 log units) above it, within the range that was stated.
By their numbers in this assay, from the lowest: compounds 3, 1 and 2 (each within the scatter of the next).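

In this assay the step for fluoro in place of hydrogen on this aromatic carbon, ortho to a trifluoromethyl group, is a 1.1-fold lower number from compound 1 to compound 3 (0.05 log units; within the scatter) and so gives no readable difference. At this position, then, a single fluoro leaves the number indistinguishable from that of compound 1. Nothing measured here speaks to the reason for this result.

Still open, going by these compounds, is whether a different group at this same position, such as an amine, a carboxylic acid or a longer chain, would give a step beyond the scatter.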